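The source may report more compounds than this note shows. Statements on the series, on what has been measured and on what is new or still open speak of the compounds shown alone.

Compound 3 `COc1ccc(C(=O)/C=C/c2cc(-c3cc(OC)c(OC)c(OC)c3)n[nH]2)cc1` is one of three close relatives tested for their power to kill a human kidney-cancer cell line in a functional assay on ACHN cells (Homo sapiens) for inhibition, read by sulforhodamine B assay, with a stated time of 48 h; on this read-out lower numbers stand for higher toxicity in this test and higher numbers for lower toxicity in this test. In this assay compound 3 gives 6710 nM. Its nearest neighbour is compound 2 `COc1ccc(C(=O)/C=C/c2cc(-c3cc(OC)c(OC)c(OC)c3)n[nH]2)cc1OC`, which in this assay gives 5750 nM; between them there is a 1.2-fold higher number from compound 2 to compound 3 (0.07 log units; within the scatter), so on the numbers shown compound 3 and compound 2 sit together and cannot be told apart. The third member, compound 1 `COc1cc(-c2cc(/C=C/C(=O)c3ccc(Cl)c(Cl)c3)[nH]n2)cc(OC)c1OC`, carries a 3,4-dichlorophenyl group on the carbonyl carbon. In this assay compound 1 gives only > 100000 nM, which is a limit of the test rather than a number. Putting a methoxy-bearing phenyl in place of that dichlorophenyl produced an at least 17-fold lower number from compound 1 to compound 2 (1.24 log units; beyond the scatter) and an at least 14-fold lower number from compound 1 to compound 3 (1.17 log units; beyond the scatter), both well beyond the scatter.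

Compound 4 `COc1cc(-c2cc(/C=C/C(=O)c3ccc(F)c(F)c3)[nH]n2)cc(OC)c1OC` turns back toward the halogen pattern: 3,4-difluorophenyl in place of 4-methoxyphenyl on a carbonyl carbon. The two large steps from compound 1 bear directly on this change, since they show that trading two ring halogens for methoxy groups lowered the number greatly, and the reverse trade is expected to raise it, possibly up to the limit of > 100000 nM in this assay, at which 1 of the 3 values shown sits. Compound 4 is therefore estimated at 50000 nM, with a likely range from 15000 nM to 150000 nM. This expected step would be a 7.5-fold higher number from compound 3 to compound 4 (0.87 log units; beyond the scatter).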

Compound 4, concentration lethal to 50% of the cells: > 100000 nM
Compound 4: a limit, no number; the forecaster's own chance of this, stated with the estimate: 40%; at least 2.0-fold (0.30 log units) between middle value and limit.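

In this assay the change to 3,4-difluorophenyl on the carbonyl carbon gives an at least 14-fold higher number from compound 3 to compound 4 (1.17 log units; beyond the scatter) and an at least 17-fold higher number from compound 2 to compound 4 (1.24 log units; beyond the scatter), so the large gap first seen with the 3,4-dichlorophenyl group of compound 1 appears again with a second pair of ring halogens. Among these four compounds, the two with ring halogens at this place both stop at a limit of the test, while the two with methoxy groups there both give readable numbers: the limit of > 100000 nM in this assay, at which 2 of the 4 values shown sit.

The step from compound 1 to compound 4 cannot be read, as both results are limits, so chlorine and fluorine cannot be ranked against each other here.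

The compounds shown do not tell whether the methoxy groups are needed for a readable number or whether the two ring halogens are what push the result to the limit. From the compounds shown here alone, a plain phenyl group, a hydroxyphenyl group or an aminophenyl group on the same carbonyl carbon would be the kind of change that separates these two readings, and how such groups would fall in this test remains open.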